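Shortening the Propylamino Chain of Compound 3

This account rests on a few compounds, and the source may have more. Where it says the series, first, only, none or still open, it means among the compounds named here.

In a physicochemical assay for lipophilicity, in phosphate buffer, measured as octanol-water partition, at pH 11.5 (a lower number here means a more polar compound, a higher number a more lipophilic compound), compound 1 (`CCCCCCCCCCOC(=N)NC(=N)Nc1ccc(Cl)cc1`) gives 6.32 and compound 2 (`CCCCCCCCCCCCNC(=N)NC(=N)Nc1ccc(Cl)cc1`) gives 7.13. Compound 3 (`CCCNC(=N)NC(=N)Nc1ccc(Cl)cc1`), at 2.63, is the lowest of the three, beyond the scatter from both others. Compound 4 (`CCNC(=N)NC(=N)Nc1ccc(Cl)cc1`) differs from compound 3 by one change: hydrogen in place of methyl on a saturated chain carbon, two bonds along the chain from an amine nitrogen, so that propylamino becomes ethylamino. Among the compounds with values here, no measured pair shows this change alone. With the longer-chained compound 2 at 7.13 and compound 3 at 2.63, a modest fall in this assay is expected, probably just beyond the scatter. The expected step is a number 0.48 log units lower from compound 3 to compound 4 (beyond the scatter). For compound 4 the estimate is 2.15, within a range of 1.8 to 2.5.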

Compound 4, partition coefficient: 2.14
Beside the measured number, compound 4's estimate is 0.01 log units above it, and the stated range covers the measured number.
By their numbers in this assay, from the lowest: compound 4; then compound 3; then compound 1; then compound 2.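

In this assay, hydrogen in place of methyl on a saturated chain carbon, two bonds along the chain from an amine nitrogen, gives a number 0.49 log units lower from compound 3 to compound 4 (beyond the scatter), a modest step. This puts a size on the change from propylamino to ethylamino, which compound 1, compound 2 and compound 3 could not give, as no two of them formed a pair differing in one place. Nothing at hand accounts for the size of this step. The compounds shown leave open whether methylamino would extend the step, and how a hydroxyl or a carboxylic acid at this chain carbon would read in this assay.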